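A few compounds are considered here, and "the series" means these few. Any claim that something is new, unique, unknown or untested is made for them only; others in the source may bear on it.

Measured in an ADME assay on MSTO-211H cells (Homo sapiens) for inhibition, read by trypan blue exclusion, with a stated time of 72 h; on this read-out lower numbers stand for stronger inhibition of growth and higher numbers for weaker inhibition of growth:
- compound 1 `O=C(/C=C/c1ccccc1)c1cccc([N+](=O)[O-])c1`: 10300 nM
- compound 2 `COc1cccc(C(=O)/C=C/c2ccccc2)c1`: 14800 nM
- compound 3 `O=C(/C=C/c1ccccc1)c1ccc(C(F)(F)F)cc1`: > 20000 nM, a limit of the assay

Compound 2 has a single numeric neighbour, compound 1, and the two sit together: the step is a 1.4-fold higher number from compound 1 to compound 2 (0.16 log units; within the scatter), methoxy in place of nitro on an aromatic carbon. Compound 3 stands at the limit of > 20000 nM in this assay, at which 1 of the 3 values shown sits, which is a limit and not a number.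

Next comes compound 4 `O=C(/C=C/c1ccccc1)c1cccc(C(F)(F)F)c1`, which keeps the core of compound 2 and differs in one group: trifluoromethyl in place of methoxy on an aromatic carbon. In words, this is trifluoromethyl in place of methoxy on an aromatic carbon, meta to a large group.

Within the data shown here, the one measured exchange of a single group on the series is a 1.4-fold higher number from compound 1 to compound 2 (0.16 log units; within the scatter), and it stayed inside the scatter. Compound 3 also carries trifluoromethyl, and its reading of > 20000 nM is a limit.

In this assay, no step beyond the scatter is therefore expected, although a reading that reports only a limit remains possible. The estimated step is a 1.1-fold higher number from compound 2 to compound 4 (0.03 log units; within the scatter). For compound 4 the expected value is 16000 nM, with an estimated range from 8500 nM to 28000 nM.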

Compound 4, concentration for 50% growth inhibition: > 20000 nM
Compound 4: a limit, no number (the forecaster's own chance of this, stated with the estimate: 35%); middle value at least 1.2-fold (0.09 log units) away from the limit.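

In this assay, the exchange at this position reads as an at least 1.3-fold higher number from compound 2 to compound 4 (0.13 log units; that floor lies within the scatter) for trifluoromethyl in place of methoxy, and as an at least 1.9-fold higher number from compound 1 to compound 4 (0.28 log units; that floor lies within the scatter) for trifluoromethyl in place of nitro. Both steps are floors and not sizes, so the data show neither exchange passing the scatter, and the real distance of compound 4 from either neighbour stays undetermined. The new information is that trifluoromethyl now accompanies a limit in two compounds, compound 3 and compound 4, whereas the methoxy and nitro compounds both give numbers, though two compounds are too few to make this a rule for the series: the limit of > 20000 nM in this assay, at which 2 of the 4 values shown sit.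

On these data alone, whether trifluoromethyl on this aromatic carbon weakens growth inhibition by a little or by a lot remains open, and a numeric reading for compound 4 would be needed to tell these apart. Also open, as far as these compounds go, is how an amine or a carboxylic acid on the same aromatic carbon would read against methoxy and nitro, which so far sit within the scatter of each other.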